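A few compounds are considered here, and "the series" means these few. Any claim that something is new, unique, unknown or untested is made for them only; others in the source may bear on it.

Working notes on the series in a functional assay on ZR-75-1 cells (Homo sapiens) for inhibition, read by sulforhodamine B assay; on this read-out lower numbers stand for stronger inhibition of growth and higher numbers for weaker inhibition of growth. Compound 2 `FC(F)(F)c1ccc(-c2ccc(-c3ccc(-c4nc5ccccc5[nH]4)cc3)cc2)cc1` gives 48300 nM, and compound 3 `COc1ccc(-c2ccc(-c3ccc(-c4nc5ccccc5[nH]4)cc3)cc2)cc1OC` gives 39700 nM. The exchange of 4-(trifluoromethyl)phenyl for 3,4-dimethoxyphenyl that separates them amounts to a 1.2-fold lower number from compound 2 to compound 3 (0.09 log units; within the scatter), so the two sit together at the upper end of the numbers. Compound 1 `COc1ccc(-c2ccc(-c3ccc(-c4nc5cc(C)ccc5[nH]4)cc3)cc2)cc1OC` gives 3100 nM, clearly lower than either.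

Compound 4 `Cc1ccc2[nH]c(-c3ccc(-c4ccc(-c5ccc(C(F)(F)F)cc5)cc4)cc3)nc2c1` is reached from compound 2 by methyl in place of hydrogen on an aromatic carbon, that is, 1H-benzimidazol-2-yl to 5-methyl-1H-benzimidazol-2-yl. The same change has been measured once, in the reverse direction and with 3,4-dimethoxyphenyl at the other end of the molecule: a 13-fold higher number from compound 1 to compound 3 (1.11 log units; beyond the scatter), a large step beyond the scatter. Whether it carries over to the 4-(trifluoromethyl)phenyl compounds has not been measured, and a single pair is thin support. The step between compound 2 and compound 3 at least gives no sign that the two end groups set different starting levels.

Within the data shown here, a lower number is therefore expected, though the size is held somewhat below that of the single pair, with an estimated 6.9-fold lower number from compound 2 to compound 4 (0.84 log units; beyond the scatter). For compound 4 the estimate is 7000 nM, with an expected range of 2000 nM to 30000 nM.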

Compound 4, concentration for 50% growth inhibition: 2410 nM
Compound 4: middle estimate off by 2.9-fold (0.46 log units), on the high side, within the range that was stated.
By their numbers in this assay, from the lowest: compounds 4 and 1 (each within the scatter of the next); then compounds 3 and 2 (each within the scatter of the next).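

In this assay, 1H-benzimidazol-2-yl to 5-methyl-1H-benzimidazol-2-yl gives a 20-fold lower number from compound 2 to compound 4 (1.30 log units; beyond the scatter), so the large step is no longer tied to a single pair and now appears with 4-(trifluoromethyl)phenyl as well as 3,4-dimethoxyphenyl at the other end of the molecule, with the two steps agreeing in size: the same change on two cores in this assay, a 13-fold higher number (1.11 log units; beyond the scatter) from compound 1 to compound 3 and a 20-fold higher number (1.30 log units; beyond the scatter) from compound 4 to compound 2, 1.6-fold (0.19 log units) apart, within the scatter of two such steps.

The exchange of end groups, already without visible effect in the compounds lacking the methyl, also stays within the scatter when the methyl is present, at a 1.3-fold lower number from compound 1 to compound 4 (0.11 log units; within the scatter), and the two exchanges agree: the same change on two cores in this assay, a 1.2-fold lower number (0.09 log units; within the scatter) from compound 2 to compound 3 and a 1.3-fold higher number (0.11 log units; within the scatter) from compound 4 to compound 1, 1.6-fold (0.19 log units) apart, within the scatter of two such steps.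

Across these four compounds, with none going against it, the number therefore follows the presence of the methyl and not the choice between these two end groups.

The compounds shown leave open whether the step is particular to methyl or would also follow from ethyl, methoxy, chlorine or an amine on the same aromatic carbon. They also leave open whether it persists with end groups other than these two, such as a phenyl ring carrying a carboxylic acid.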